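Hydroxy for chloroacetylamino on the shared core

This account rests on a few compounds, and the source may have more. Where it says the series, first, only, none or still open, it means among the compounds named here.

Compound 1 `Nc1cn(COC(CO)CO)c(=O)[nH]c1=O` and compound 2 `O=C(CCl)Nc1cn(COC(CO)CO)c(=O)[nH]c1=O` share one core and differ only on the ring nitrogen substituent. In a functional assay on MCF7 cells (Homo sapiens) for inhibition, read by MTT assay, with a stated time of 72 h (on this read-out lower numbers stand for stronger inhibition and higher numbers for weaker inhibition), compound 1 gives only a limit of the assay, > 100000 nM. Within the data shown here, in the same assay compound 2 gives 32000 nM, and the step of an at least 3.1-fold lower number from compound 1 to compound 2 (0.49 log units; beyond the scatter) is the single measured step of the set. Compound 2 therefore stands as the only number shown; the other value is a limit (the limit of > 100000 nM in this assay, at which 1 of the 2 values shown sits).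

Compound 3 `O=c1[nH]c(=O)n(COC(CO)CO)cc1O` is reached from compound 2 by the change (hydroxy in place of ((chloromethyl)carbonyl)amino on an aromatic carbon). Among the measured compounds shown here, no measured pair matches this change exactly. For the measured compounds named here, the one step that bears on it, an at least 3.1-fold lower number from compound 1 to compound 2 (0.49 log units; beyond the scatter), shows that taking the (chloromethyl)carbonyl away from compound 2 costs at least a modest amount of potency, and compound 3 likewise loses that group while also exchanging the nitrogen for an oxygen. Compound 3 is therefore expected to fall back toward the limit, with an estimate of 100000 nM, ranging from 30000 nM to 300000 nM, which means the expected step of a 3.1-fold higher number from compound 2 to compound 3 (0.49 log units; beyond the scatter).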

Compound 3, half-maximal inhibitory concentration: > 100000 nM
Compound 3: a limit, no number (the forecaster's own chance of this, stated with the estimate: 55%); the middle value sits exactly at the limit.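

In this assay, putting hydroxy in place of ((chloromethyl)carbonyl)amino on this aromatic carbon gives an at least 3.1-fold higher number from compound 2 to compound 3 (0.49 log units; beyond the scatter). This is the second change at this position to end at a limit of the assay, so among the three compounds a readable number appears only with the ((chloromethyl)carbonyl)amino group of compound 2, and neither amino in compound 1 nor hydroxy in compound 3 gives one. Compound 1 and compound 3 cannot be ranked against each other, and the step between them cannot be read, because both stop at a limit of the assay: the limit of > 100000 nM in this assay, at which 2 of the 3 values shown sit.

What an acetylamino group, with no chlorine, would give on this carbon stays open, so the compounds shown do not separate the part played by the chlorine from that of the rest of the group. Also open, going by these compounds, is whether a longer chain in place of the chloromethyl, or a bromoacetylamino group, would move the number of compound 2 in either direction.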